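Sulfur-linked side chain: aryl swap on the benzylic carbon

The source may report more compounds than this note shows. Statements on the series, on what has been measured and on what is new or still open speak of the compounds shown alone.

Compound 1 `CC(Sc1nc2c(cnn2C)c(=O)n1-c1ccccc1)c1ccccn1` gives 89 nM in an assay on isolated protein for inhibition of Retinaldehyde dehydrogenase 3 (Homo sapiens) (on this read-out lower numbers stand for stronger inhibition and higher numbers for weaker inhibition), the lowest number of the three measured; compound 3 `C#Cc1ccc(-n2c(SC(C)c3ccccc3)nc3c(cnn3C)c2=O)cc1` gives 520 nM and compound 2 `Cn1ncc2c(=O)n(-c3ccccc3)c(SC(C)(C)c3ccccc3)nc21` gives 1390 nM. Compound 4 `COc1ccccc1C(C)Sc1nc2c(cnn2C)c(=O)n1-c1ccccc1` is the next variation on compound 1: 2-methoxyphenyl in place of pyridin-2-yl on a saturated chain carbon bound to a saturated chain carbon and a sulfur. Within the data shown here, the one measured step that bears on changes at this sulfur-bound chain is a 16-fold higher number from compound 1 to compound 2 (1.19 log units; beyond the scatter), which also alters the chain itself, so it is only a rough guide; compound 3 differs from compound 1 in two places and its number can only be read as a hint that phenyl-type groups here run weaker. A moderate loss is therefore expected, a 3.4-fold higher number from compound 1 to compound 4 (0.53 log units; beyond the scatter). Compound 4 is estimated at 300 nM, within 100 nM to 900 nM.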

Compound 4, half-maximal inhibitory concentration: 112 nM
Estimate against measurement, compound 4: 2.7-fold (0.43 log units) above; the range from low to high includes it.
By their numbers in this assay, from the lowest: compounds 1 and 4 (each within the scatter of the next); then compound 3; then compound 2.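

The step of a 1.3-fold higher number from compound 1 to compound 4 (0.10 log units; within the scatter) puts 2-methoxyphenyl and pyridin-2-yl level on this saturated chain carbon, so a six-membered aromatic ring of carbon only can stand here without a measurable change. The step of a 16-fold higher number from compound 1 to compound 2 (1.19 log units; beyond the scatter) is large. That step places 1-methyl-1-phenylethyl where 1-(pyridin-2-yl)ethyl stood, and so it alters the chain itself as well as the ring. Nothing available explains why these two groups read alike.

Still open, on these data alone, is whether a carboxylic acid or an amine on this aryl ring would keep the number. Also open, as far as these compounds go, is whether pyridin-3-yl would read like pyridin-2-yl.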